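The source may report more compounds than this note shows. Statements on the series, on what has been measured and on what is new or still open speak of the compounds shown alone.

Of the compounds shown here, three from one series have been measured for how strongly they slow the growth of a human prostate cancer cell line, and a fourth awaits its number.

Compound 1 `C=CC(=O)Nc1cc2c(N3CCc4ccccc43)ncnc2cc1OC` is the reference. In a functional assay on PC-3 cells (Homo sapiens) for antiproliferative activity, read by MTT assay, with a stated time of 72 h (on this read-out higher numbers stand for weaker inhibition and lower numbers for stronger inhibition), compound 1 gives 5940 nM. Compound 2 `C=C(C)C(=O)Nc1cc2c(N3CCc4ccccc43)ncnc2cc1OC` differs from it in one place, (methyl in place of hydrogen on a double-bonded chain carbon bound to a carbonyl carbon), and in this assay compound 2 gives 4830 nM; the step of a 1.2-fold lower number from compound 1 to compound 2 (0.09 log units; within the scatter) is small enough that the two numbers cannot be told apart.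

Compound 3 `C=CC(=O)Nc1cc2c(N3CCc4ccccc43)ncnc2cc1O[C@@H]1CCOC1` keeps the acrylamide of compound 1 but carries a different change, (oxolan-3-yl in place of methyl on an oxygen on an aromatic ring). In this assay compound 3 gives 2710 nM, and the step of a 2.2-fold lower number from compound 1 to compound 3 (0.34 log units; beyond the scatter) is the one clear movement seen so far; against compound 2 its number is close enough to count as the same.

Compound 4 `C=C(C)C(=O)Nc1cc2c(N3CCc4ccccc43)ncnc2cc1O[C@@H]1CCOC1` has not yet been measured. It stands to compound 3 exactly as compound 2 stands to compound 1: the change is methyl in place of hydrogen on a double-bonded chain carbon bound to a carbonyl carbon, and the two cores differ by oxolan-3-yl in place of methyl on an oxygen on an aromatic ring. Because the earlier instance of this same change gave a 1.2-fold lower number from compound 1 to compound 2 (0.09 log units; within the scatter), the expectation is that moving from compound 3 to compound 4 in this assay will again be a small step, a 1.2-fold lower number from compound 3 to compound 4 (0.07 log units; within the scatter). For compound 4 the estimate is 2300 nM, likely between 1200 nM and 4500 nM.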

Compound 4, half-maximal inhibitory concentration: 4910 nM
The estimate for compound 4 lay 2.1-fold (0.33 log units) below the measured number; the measured number lies above the stated range.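

In this assay, methyl in place of hydrogen on a double-bonded chain carbon bound to a carbonyl carbon gives a 1.8-fold higher number from compound 3 to compound 4 (0.26 log units; within the scatter), and this step does not differ from its earlier instance on the core of compound 1 by more than the scatter allows: the same change on two cores in this assay, a 1.2-fold lower number (0.09 log units; within the scatter) from compound 1 to compound 2 and a 1.8-fold higher number (0.26 log units; within the scatter) from compound 3 to compound 4, 2.2-fold (0.35 log units) apart, within the scatter of two such steps. The other change, oxolan-3-yl in place of methyl on an oxygen on an aromatic ring, gives a 1.0-fold higher number from compound 2 to compound 4 (0.01 log units; within the scatter), and even though only its earlier instance lies beyond the scatter, the two steps cannot be told apart: the same change on two cores in this assay, a 2.2-fold lower number (0.34 log units; beyond the scatter) from compound 1 to compound 3 and a 1.0-fold higher number (0.01 log units; within the scatter) from compound 2 to compound 4, 2.2-fold (0.35 log units) apart, within the scatter of two such steps. So the four compounds show no sign that either change behaves differently on the two cores, but that is an absence of evidence rather than proof of transfer, since each comparison rests on just two steps and a real difference of this size could stay hidden in the scatter.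

On these data alone, it remains open whether the same would hold for a longer chain such as ethyl in place of the methyl on the double-bonded chain carbon, or for a chain ending in an amine in place of oxolan-3-yl on the oxygen. As far as these compounds go, it also remains open whether these steps would look the same on any other cell line.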